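A methyl added to the benzimidazole of a cathepsin S inhibitor

A few compounds are considered here, and "the series" means these few. Any claim that something is new, unique, unknown or untested is made for them only; others in the source may bear on it.

Compound 1 `CC(=O)N1CCc2c(c(-c3ccc(OC(F)(F)F)cc3)nn2CC(O)CN2CCC(n3c(O)nc4ccccc43)CC2)C1`: 130 nM
Compound 2 `CC(=O)N1CCc2c(c(-c3ccc(I)cc3)nn2CC(O)CN2CCC(n3c(O)nc4ccccc43)CC2)C1`: 120 nM
Compound 3 `CC(=O)N1CCc2c(c(-c3ccc(Br)cc3)nn2CC(O)CN2CCC(n3c(O)nc4ccccc43)CC2)C1`: 80 nM

All three were tested in an assay on isolated protein for inhibition of cathepsin S (Homo sapiens); a higher number here means a weaker inhibitor, a lower number a stronger inhibitor. Compound 3 gives the lowest of the three numbers, but a 1.5-fold lower number from compound 2 to compound 3 (0.18 log units; within the scatter) and a 1.6-fold lower number from compound 1 to compound 3 (0.21 log units; within the scatter), so the three stand together. Compound 4 `CC(=O)N1CCc2c(c(-c3ccc(Br)cc3)nn2CC(O)CN2CCC(n3c(O)nc4cccc(C)c43)CC2)C1` is not yet measured; it differs from compound 3 by methyl in place of hydrogen on an aromatic carbon, that is, 2-hydroxy-1H-benzimidazol-1-yl becomes 2-hydroxy-7-methyl-1H-benzimidazol-1-yl. Among the compounds with values here, none of the measured steps touches this part of the structure: a 1.1-fold lower number from compound 1 to compound 2 (0.03 log units; within the scatter), a 1.6-fold lower number from compound 1 to compound 3 (0.21 log units; within the scatter) and a 1.5-fold lower number from compound 2 to compound 3 (0.18 log units; within the scatter) all concern the other aromatic ring, and all are small. Within the data shown here, with no step bearing on the change, no shift beyond the scatter is expected, so no change at the digits printed from compound 3 to compound 4 (within the scatter) is the estimate. Compound 4 is therefore expected to give about 80 nM, within 35 nM to 180 nM.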

Compound 4, half-maximal inhibitory concentration: 210 nM
The estimate for compound 4 lay 2.6-fold (0.42 log units) below the measured number; the measured number lies above the stated range.
By their numbers in this assay, from the lowest: compounds 3, 2, 1 and 4 (each within the scatter of the next, the first and the last beyond it).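

The 2-hydroxy-1H-benzimidazol-1-yl group, which no earlier step touched, is not indifferent to substitution: in this assay, the change to 2-hydroxy-7-methyl-1H-benzimidazol-1-yl gives a 2.6-fold higher number from compound 3 to compound 4 (0.42 log units; beyond the scatter), the only step shown that lies beyond the scatter. A single added methyl here moves the number further than any exchange on the other aromatic ring among compounds 1, 2 and 3. Nothing available explains this shift. Going by these compounds, whether fluoro, chloro or methoxy at this carbon would shift the number likewise remains open. So does whether methyl has the same effect alongside the iodo of compound 2 or the trifluoromethoxy of compound 1.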